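Cyclopentyl for trifluoromethyl on the benzylamide of the sulfonamide series

The source may report more compounds than this note shows. Statements on the series, on what has been measured and on what is new or still open speak of the compounds shown alone.

Measured so far:
compound 1, `CC(C)(C)c1ccc(CNC(=O)C2(c3ccc(NS(C)(=O)=O)cc3)CC2)cc1`: 610 nM
compound 2, `CC(C(=O)NCc1ccc(C(F)(F)F)cc1)c1ccc(NS(C)(=O)=O)c(F)c1`: 660 nM

In an assay on CHO cells for displacement of a labelled ligand from transient receptor potential cation channel subfamily V member 1 (Rattus norvegicus) (on this read-out lower numbers stand for stronger inhibition and higher numbers for weaker inhibition), compound 2 gives 660 nM, the higher of the two numbers recorded, while compound 1 gives 610 nM; the two lie within the scatter of each other. Compound 3, `CC(C(=O)NCc1ccc(C2CCCC2)cc1)c1ccc(NS(C)(=O)=O)c(F)c1`, differs from compound 2 by cyclopentyl in place of trifluoromethyl on an aromatic carbon. Within the data shown here, no measured pair shows this change, so the expected step in this assay is small, with no direction beyond the scatter. Estimated: a 1.5-fold lower number from compound 2 to compound 3 (0.17 log units; within the scatter). Compound 3 is expected at 450 nM, range 120 nM to 1800 nM.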

Compound 3, inhibition constant: 93 nM
Beside the measured number, compound 3's estimate is 4.8-fold (0.68 log units) above it, and the stated range ends above it.
By their numbers in this assay, from the lowest: compound 3; then compounds 1 and 2 (each within the scatter of the next).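

In this assay, cyclopentyl in place of trifluoromethyl on an aromatic carbon, para to a large group, gives a 7.1-fold lower number from compound 2 to compound 3 (0.85 log units; beyond the scatter). Among these compounds, this is the first step that changes one place only, so the substituent at this position now has a measured effect on the number, which compounds 1 and 2 could not show. Nothing measured here bears on the reason for the step.

Open, on these data alone, is how a cyclohexyl, phenyl or morpholine ring would read at this position. Also open, as far as these compounds go, is whether the step carries over to the core of compound 1.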